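The source may hold more compounds than are shown below. What is called first, only, known or untested is meant among the compounds shown, and "the series" means these compounds.

Measured in a functional assay on BGC-823 cells (Homo sapiens) for inhibition, read by MTT assay, with a stated time of 72 h; on this read-out higher numbers stand for weaker inhibition and lower numbers for stronger inhibition:
Compound 1, `Cc1cc(N2CC[C@@H](C)[C@@H](N(C)c3ncnc4[nH]ccc34)C2)n2ncnc2n1`: 67400 nM
Compound 2, `CCCSc1nc2nc(C)cc(N3CC[C@@H](C)[C@@H](N(C)c4ncnc5[nH]ccc45)C3)n2n1`: 51200 nM
Compound 3, `Cc1cc(N2CC[C@@H](C)[C@@H](N(C)c3ncnc4[nH]ccc34)C2)n2nc(SCc3nc4ccccc4[nH]3)nc2n1`: only a limit of the assay, > 100000 nM

All three share one core and differ only in the group on one aromatic carbon of it. Of the two numbers, compound 2 gives the lower, yet compound 1 sits within the scatter of it, as the step of a 1.3-fold lower number from compound 1 to compound 2 (0.12 log units; within the scatter) shows. Compound 4, `Cc1cc(N2CC[C@@H](C)[C@@H](N(C)c3ncnc4[nH]ccc34)C2)n2nc(SCc3ccc([N+](=O)[O-])cc3)nc2n1`, is still to be measured in this assay. It differs from compound 2 by 4-nitrophenyl in place of ethyl on a saturated chain carbon bound to a sulfur; cut one bond further out, propylsulfanyl becomes (4-nitrobenzyl)sulfanyl. The closest guide is the step of an at least 1.9-fold higher number from compound 2 to compound 3 (0.29 log units; that floor lies within the scatter), in which a larger ring likewise replaced the ethyl on that carbon. For compound 3 the assay returned only its limit (the limit of > 100000 nM in this assay, at which 1 of the 3 values shown sits). The step of an at least 1.4-fold higher number from compound 1 to compound 3 (0.17 log units; that floor lies within the scatter) reads the same way. Neither step exceeds the scatter at its known floor, so the expectation is a number near that of compound 2 or somewhat higher. The expected step is a 1.8-fold higher number from compound 2 to compound 4 (0.24 log units; within the scatter). Compound 4 is therefore estimated at 90000 nM, within a range from 45000 nM to 200000 nM, with a real chance that only a limit is returned.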

Compound 4, half-maximal inhibitory concentration: 59600 nM
For compound 4 the middle estimate is 1.5-fold (0.18 log units) above the measured one; the range from low to high includes it.
By their numbers in this assay, from the lowest: compounds 2, 4 and 1 (each within the scatter of the next). At a limit, above all of these: compound 3.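

In this assay, a group carrying a six-membered aromatic ring on the saturated chain carbon bound to the sulfur now gives a number rather than a limit, and that number lies within the scatter of both smaller neighbours: a 1.2-fold higher number from compound 2 to compound 4 (0.07 log units; within the scatter), and a 1.1-fold lower number from compound 1 to compound 4 (0.05 log units; within the scatter). Hydrogen, propylsulfanyl and (4-nitrobenzyl)sulfanyl on this aromatic carbon therefore cannot be told apart in this assay, even though the change is large in heavy atoms. The comparison with the other ring-bearing group starts from a limit of the assay, and the step, an at least 1.6-fold lower number from compound 3 to compound 4 (0.22 log units; that floor lies within the scatter), does not show that the two groups differ.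

As far as these compounds go, the true value of compound 3 stays unknown. Also open, from the compounds shown here alone, is whether a benzyl group carrying an amine or a carboxylic acid, or a longer chain on the sulfur, would move the number beyond the scatter.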